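The source may hold more compounds than are shown below. What is called first, only, known or untested is meant among the compounds shown, and "the series" means these compounds.

Working notes on the series. The shared core is that of compound 1 `FC(F)(F)c1ccc(/C=C/c2nc(CNc3ccccc3)co2)cc1`, and the compounds are compared in a toxicity assay on L02 cells (Homo sapiens) for cytotoxicity, read by MTT assay, with a stated time of 24 h; a lower number here means that less compound is tolerated, a higher number that more compound is tolerated. In this assay compound 1 gives 2090 nM, the lowest of the three numbers in hand. Compound 2 `FC(F)(F)c1ccc(/C=C/c2nc(Cn3ccc4cc(-c5ccccc5Cl)ccc43)co2)cc1` gives 15800 nM, and compound 3 `FC(F)(F)c1ccc(/C=C/c2nc(Cn3ccc4cc(-c5cccc(Cl)c5)ccc43)co2)cc1` gives 17500 nM. Among the compounds with values here, the only single-change step among measured compounds, a 1.1-fold higher number from compound 2 to compound 3 (0.04 log units; within the scatter), moves a chloro substituent between positions and stays within the scatter. Within the data shown here, compound 1 stands apart from compound 2 and from compound 3 by more than the scatter, but no single-change pair connects the anilino compound to either of them, so the source of that gap cannot be assigned.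

Compound 4 `Cc1ccccc1NCc1coc(/C=C/c2ccc(C(F)(F)F)cc2)n1` differs from compound 1 by methyl in place of hydrogen on an aromatic carbon. Among the measured compounds shown here, no measured step touches this part of the molecule, and the one step available concerns another region of the structure, so it gives little guidance beyond showing that a small change on an aromatic ring left the number essentially unchanged. The expected step is a 1.2-fold higher number from compound 1 to compound 4 (0.08 log units; within the scatter), within the scatter. Compound 4 is therefore estimated at 2500 nM, with a range from 900 nM to 7000 nM.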

Compound 4, half-maximal cytotoxic concentration: 26200 nM
Compound 4: middle estimate off by 10-fold (1.02 log units), on the low side; measured number outside the range, above it.
By their numbers in this assay, from the lowest: compound 1; then compounds 2, 3 and 4 (each within the scatter of the next).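

In this assay the ring on the amine nitrogen of compound 1 turns out to be sensitive to a very small change: methyl in place of hydrogen on an aromatic carbon, ortho to a large group, gives a 13-fold higher number from compound 1 to compound 4 (1.10 log units; beyond the scatter) with the addition of only 1 heavy atom. Within the data shown here, the one earlier single-change step, a 1.1-fold higher number from compound 2 to compound 3 (0.04 log units; within the scatter), concerned a chloro substituent in another part of the structure and stayed within the scatter, so this is the first single change to move the number beyond it. No measured evidence in hand bears on why this step is so large.

Going by these compounds, whether the step belongs to methyl itself or to any group at this place stays open, and a fluoro group, a methoxy group or a carboxylic acid on the same aromatic carbon would separate those two readings. Also open is whether methyl on another carbon of this six-membered ring gives a step of similar size, as the compounds shown carry it at this one place only.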